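Moving the chlorine: from compound 2 to compound 4

The compounds below may be only part of what the source reports. "The series", "measured", "known", "first", "only" and "open" are said of these compounds alone.

- compound 1 `CCCCc1[nH]c(=O)c(-c2n[nH]c(Cc3ccccc3)n2)c(O)c1-c1c(OC)cccc1OC`: 15%
- compound 2 `CCCCc1[nH]c(=O)c(-c2nnc(Cc3ccccc3Cl)o2)c(O)c1-c1c(OC)cccc1OC`: 24%
- compound 3 `CCCCc1[nH]c(=O)c(C(=O)OCC)c(O)c1-c1c(OC)cccc1OC`: 24%

In an ADME assay on microsomes from liver (Rattus norvegicus) for metabolic stability, read by mass spectrometry, using NADPH, with a stated time of 10 min (on this read-out higher numbers stand for a more stable compound and lower numbers for a less stable compound), compound 2 gives 24%, level with compound 3 at 24%. Compound 1 at 15% stays within the scatter of both.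

Compound 4 `CCCCc1[nH]c(=O)c(-c2nnc(Cc3ccc(Cl)cc3)o2)c(O)c1-c1c(OC)cccc1OC` differs from compound 2 by 4-chlorophenyl in place of 2-chlorophenyl on a saturated chain carbon bound to an aromatic carbon. No measured step among these compounds speaks to this change, so the expectation rests on compound 2 at 24%. The expected step is a number 2 percentage points lower from compound 2 to compound 4 (within the scatter), with no move beyond the scatter and no firm direction in this assay. Compound 4 is estimated at 22%, with an expected range of 10% to 36%.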

Compound 4, percent of the compound remaining: 22%
For compound 4 middle estimate and measured number coincide at the digits printed; measured number inside the range.
By their numbers in this assay, from the lowest: compounds 1, 4, 2 and 3 (each within the scatter of the next).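

In this assay, for the compounds shown here, the swap of 2-chlorophenyl for 4-chlorophenyl on a saturated chain carbon bound to an aromatic carbon gives a step of a number 2 percentage points lower from compound 2 to compound 4 (within the scatter) and provides the first comparison that differs in one place. At this position, the two chlorophenyl groups are not separated by this read-out. No measured evidence bears on this result.

On these data alone, it remains open whether an amine or a carboxylic acid on this phenyl ring would shift the number beyond the scatter. Also open, as far as these compounds go, is whether a longer chain in place of the butyl chain would do so.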